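Shorter aryl substituent with fluorine on the shared core

This account rests on a few compounds, and the source may have more. Where it says the series, first, only, none or still open, it means among the compounds named here.

Compound 1 `CCCc1ccc(-c2cc(=O)c3c(o2)C(CC)(CC)C(=O)C(CC)=C3O)cc1` has the highest number of the three measured compounds in a functional assay on KBVIN cells (Homo sapiens) for antiproliferative activity, read by sulforhodamine B assay, with a stated time of 3 days (a lower number here means that less compound is needed, a higher number that more compound is needed for the effect), where compound 1 gives 12.2 uM. Compound 2 `CCC1=C(O)c2c(oc(-c3ccc(C(C)C)cc3)cc2=O)C(CC)(CC)C1=O` gives 1.08 uM, and compound 3 `CCC1=C(O)c2c(oc(-c3ccccc3C)cc2=O)C(CC)(CC)C1=O` gives 2.41 uM. The step of an 11-fold lower number from compound 1 to compound 2 (1.05 log units; beyond the scatter) and the step of a 5.1-fold lower number from compound 1 to compound 3 (0.70 log units; beyond the scatter) both move away from the 4-propylphenyl group of compound 1 and both lower the number, while between those two compounds the step of a 2.2-fold higher number from compound 2 to compound 3 (0.35 log units; beyond the scatter) is smaller. Compound 4 `CCC1=C(O)c2c(oc(-c3ccc(C)c(F)c3)cc2=O)C(CC)(CC)C1=O` differs from compound 1 in one place: 3-fluoro-4-methylphenyl in place of 4-propylphenyl on an aromatic carbon. Both measured departures from compound 1 bear on this change, so a lower number in this assay is expected, with an expected step of a 4.1-fold lower number from compound 1 to compound 4 (0.61 log units; beyond the scatter). Compound 4 is therefore estimated at 3 uM, with a range from 1 uM to 9 uM.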

Compound 4, concentration for half-maximal effect: 2.95 uM
Compound 4: middle estimate off by 1.0-fold (0.01 log units), on the high side; low and high end bracket the measured number.
By their numbers in this assay, from the lowest: compound 2; then compounds 3 and 4 (each within the scatter of the next); then compound 1.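

In this assay, a third aryl group also lowers the number relative to the 4-propylphenyl group of compound 1 (a 4.1-fold lower number from compound 1 to compound 4 (0.62 log units; beyond the scatter)), so compound 1 stays the highest of the four. The 3-fluoro-4-methylphenyl group cannot be told apart from the 2-methylphenyl group (a 1.2-fold higher number from compound 3 to compound 4 (0.09 log units; within the scatter)), but it does not match the 4-isopropylphenyl group (a 2.7-fold higher number from compound 2 to compound 4 (0.44 log units; beyond the scatter)). No measurement given here explains these differences. Still open, from the compounds shown here alone, is how this aryl ring would behave with an amine or a carboxylic acid in place of the methyl group of compound 4.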